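The source may hold more compounds than are shown below. What is called first, only, known or untested is meant among the compounds shown, and "the series" means these compounds.

Working notes on the series.

Compound 1, `O=C1c2sc(C#Cc3ccccc3)nc2CN1C1CC1`, is the carbonyl-bearing member of the set. In an assay on HEK293 cells for positive allosteric modulation of metabotropic glutamate receptor 5 (Homo sapiens), read by FLIPR, with a stated time of 1 h (on this read-out higher numbers stand for an effect only at larger amounts of compound and lower numbers for an effect already at smaller amounts), compound 1 returns only the assay limit, > 10000 nM. Compound 2, `CCN1CCc2nc(C#Cc3ccccc3)sc2C1`, carries an ethyl on the amine nitrogen in the ring. In this assay compound 2 likewise gives only the limit, > 10000 nM, so no number is known for it, and it stands with compound 1 at the limit of > 10000 nM in this assay, at which 2 of the 3 values shown sit. Going by the values given here, compound 3, `O=C(C1CC(F)(F)C1)N1CCc2nc(C#Cc3cccc(F)c3)sc2C1`, is the only member with a real number: in this assay compound 3 gives 2.5 nM. Compound 3 differs from compound 2 both at the amine nitrogen in the ring and on the phenyl, so its gap to compound 2 cannot be laid on one change.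

Compound 4, `CC(C)S(=O)(=O)N1CCc2nc(C#Cc3ccccc3)sc2C1`, is not yet measured. From compound 2 to compound 4 the change is isopropylsulfonyl in place of ethyl on an amine nitrogen in a ring. This moves the substituent on the ring nitrogen toward the kind of substitution seen in compound 3 rather than compound 2. The step from compound 2 to compound 4 is expected to be large and toward an effect at smaller amounts, well beyond the scatter, an at least 250-fold lower number from compound 2 to compound 4 (2.39 log units; beyond the scatter), though with compound 3 as the only anchor the size is uncertain. Compound 4 is estimated at 40 nM, expected between 5 nM and 400 nM.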

Compound 4, half-maximal effective concentration: > 10000 nM
Compound 4 ended at the assay's limit; the forecaster's own chance of this, stated with the estimate: 15%; middle value at least 250-fold (2.39 log units) from the limit.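

Compound 2 and compound 4 both stand at the limit of this assay, so isopropylsulfonyl in place of ethyl gives no readable step between them: the limit of > 10000 nM in this assay, at which 3 of the 4 values shown sit. The compounds shown leave open what isopropylsulfonyl on an amine nitrogen in a ring does by itself, and which difference between compound 2 and compound 3 goes with 2.5 nM.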